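This account rests on a few compounds, and the source may have more. Where it says the series, first, only, none or still open, it means among the compounds named here.

Working notes on the series in an assay on HEK-293T cells for inhibition of diacylglycerol lipase-alpha (Homo sapiens), read by colorimetric assay; a higher number here means a weaker inhibitor, a lower number a stronger inhibitor. Compound 1 `O=C(CCCCCCc1ccccc1)c1ccc(-c2ccco2)nn1` gives in this assay only a limit of the measurement, > 10000 nM. Compound 2 `CS(=O)(=O)c1coc(C(=O)CCCCCCc2ccccc2)n1` gives in this assay 389 nM. Where compound 2 stands: it carries the only number in the set; the other entry is the limit of > 10000 nM in this assay, at which 1 of the 2 values shown sits, so there is no measured neighbour against which its value can be ranked, and no step between measured compounds is available.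

Compound 3 `CSc1coc(C(=O)CCCCCCc2ccccc2)n1` is the next compound to be measured. It differs from compound 2 in one place: methylsulfanyl in place of methylsulfonyl on an aromatic carbon. Within the data shown here, with no measured step in the set, the size of this change cannot be read from the data and rests on expectation alone. The expectation is that compound 3 will be the weaker of the two, with a step from compound 2 to compound 3 of a 6.4-fold higher number from compound 2 to compound 3 (0.81 log units; beyond the scatter), beyond the usual scatter. The estimate for compound 3 in this assay is 2500 nM, with a range from 600 nM to 10000 nM, and some chance that only a limit is reported.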

Compound 3, half-maximal inhibitory concentration: > 10000 nM
Compound 3: a limit, no number (the forecaster's own chance of this, stated with the estimate: 25%); at least 4.0-fold (0.60 log units) between middle value and limit.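

In this assay, the series gains its first measured step at this position, an at least 25-fold higher number from compound 2 to compound 3 (1.41 log units; beyond the scatter), on replacing methylsulfonyl with methylsulfanyl on the aromatic carbon next to the ring nitrogen. With the rest of the structure unchanged, the group on this one carbon decides whether the pair gives a number at all, and of the two only methylsulfonyl does. The step is a lower bound and not a measured size, because compound 3 gives only a limit: the limit of > 10000 nM in this assay, at which 2 of the 3 values shown sit.

The compounds shown leave open how a nitrile, a carboxylic acid or a primary amide on this carbon would compare with methylsulfonyl, and whether a methylsulfinyl group would give a value between those of the two sulfur groups. They also leave open whether the dependence on methylsulfonyl would persist with a longer chain on the carbonyl, and how far the true value of compound 3 lies beyond its limit.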